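One Methyl Added on the Way to Compound 3

The compounds below may be only part of what the source reports. "The series", "measured", "known", "first", "only" and "open" are said of these compounds alone.

Of the compounds shown here, two of a shared core have been measured in a functional assay on HuCC-A1 cells (Homo sapiens) for cytotoxicity, read by MTT assay; a lower number here means a stronger inhibitor, a higher number a weaker inhibitor. Compound 1 `COc1cc(O)c(C=O)c2c1[C@H](OC)C[C@@H](c1ccccc1)O2` gives 140000 nM in this assay. Compound 2 `COc1c(C)c(O)c(C=O)c2c1[C@H](O)C[C@@H](c1ccccc1)O2` gives 143000 nM in this assay, and that value sits within the usual scatter of the value of compound 1, so the two numbers cannot be told apart and neither compound can be called the more or the less potent.

Compound 3 `COc1c(C)c(O)c(C=O)c2c1[C@H](OC)C[C@@H](c1ccccc1)O2` has not yet been measured. It differs from compound 2 in one place: methyl in place of hydrogen on an oxygen on a saturated carbon. Compound 1 already carries this methoxy but differs from compound 2 elsewhere as well, and the two values of compound 1 and compound 2 show no separation beyond the scatter. For the measured compounds named here, no measured pair isolates the hydroxy to methoxy exchange alone on this core, so the expectation for compound 3 rests on that thin basis. The expected change in this assay, a 1.0-fold lower number from compound 2 to compound 3 (0.01 log units; within the scatter), is none beyond the scatter, in either direction. Compound 3 is therefore estimated at 140000 nM, within a range from 50000 nM to 350000 nM.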

Compound 3, half-maximal inhibitory concentration: 125000 nM
Compound 3: the middle estimate sits 1.1-fold (0.05 log units) above what was measured; measured number inside the range.
By their numbers in this assay, from the lowest: compounds 3, 1 and 2 (each within the scatter of the next).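

For the compounds shown here, with compound 3 in hand, the hydroxy to methoxy exchange on the saturated carbon stands alone for the first time. In this assay this methyl in place of hydrogen on an oxygen leaves the values of the two compounds inseparable (a 1.1-fold lower number from compound 2 to compound 3 (0.06 log units; within the scatter)), and the second single-place pair, with methyl in place of hydrogen on an aromatic carbon, gives the same reading (a 1.1-fold lower number from compound 1 to compound 3 (0.05 log units; within the scatter)). Neither of the two changes, taken alone on the shared core, therefore separates from the scatter in this assay, and no supporting measurement is available to explain this result.

The compounds shown leave open whether a longer chain on that oxygen, such as an ethoxy group, or an amine in place of the hydroxy would move the number beyond the scatter. They also leave open what a carboxylic acid on the aromatic carbon that carries the methyl would do, since all three compounds stay the same outside these two places.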